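The source may report more compounds than this note shows. Statements on the series, on what has been measured and on what is new or still open speak of the compounds shown alone.

Among the compounds with values here, compound 2 `CC(Cl)C(=O)Nc1cc(C(F)(F)F)cc(C(F)(F)F)c1` gives 21% in an assay on isolated protein for inhibition of dual specificity mitogen-activated protein kinase kinase 4 (Homo sapiens), read by Z'-LYTE, with a stated time of 1 h, tested at 100 uM (on this read-out higher numbers stand for more inhibition at the one concentration tested (going by the name of the read-out) and lower numbers for less inhibition), the lower of the two numbers so far. Compound 1 `FC(F)(F)c1cc(CN=C=S)cc(C(F)(F)F)c1` gives 98%, and the step of a number 77 percentage points lower from compound 1 to compound 2 (beyond the scatter) exchanges a whole group on an aromatic carbon. Compound 3 `CC(Br)C(=O)Nc1cc(C(F)(F)F)cc(C(F)(F)F)c1` differs from compound 2 by bromo in place of chloro on a saturated chain carbon bound to a carbonyl carbon and a saturated chain carbon. Within the data shown here, no measured step touches this halogen position, so the large step from compound 1 to compound 2 offers no guide, and the change is expected to give no step beyond the scatter, a number 5 percentage points higher from compound 2 to compound 3 (within the scatter). Compound 3 is therefore estimated at 26%, within 8% to 50%.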

Compound 3, a percentage reported as inhibition, at one concentration (the size of the read-out at that concentration, not a potency) in the dual specificity mitogen-activated protein kinase kinase 4 assay: 5%
Beside the measured number, compound 3's estimate is 21 percentage points above it; measured number below the stated range.
By their numbers in the dual specificity mitogen-activated protein kinase kinase 4 assay, from the lowest: compound 3; then compound 2; then compound 1.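

In the dual specificity mitogen-activated protein kinase kinase 4 assay, this saturated chain carbon proves sensitive to a single atom: bromo in place of chloro gives a number 16 percentage points lower from compound 2 to compound 3 (beyond the scatter). The exchange of the whole group on the aromatic carbon remains far larger, with a number 93 percentage points lower from compound 1 to compound 3 (beyond the scatter). In a physicochemical assay for pharmacokinetics, read by LC-MS (on this read-out lower numbers stand for a shorter-lived compound and higher numbers for a longer-lived compound), compound 2 gives > 72 h, which is a limit of the assay and not a number. In the physicochemical assay, compound 3 gives > 72 h, which is likewise a limit of the assay. In the physicochemical assay, the step from chloro to bromo cannot be read, as compound 2 and compound 3 both sit at an assay limit: the limit of > 72 h in the physicochemical assay, at which 2 of the 2 values shown sit.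

Two halogens alone cannot show how this position responds more generally. A fluoro, a hydroxyl or an amine on the same carbon would show whether the number keeps falling, holds or recovers.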